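Trading a Methoxy for a Hydroxy on the Side Chain

The source may hold more compounds than are shown below. What is called first, only, known or untested is meant among the compounds shown, and "the series" means these compounds.

Going by the values given here, compound 3 `COC[C@H](C)Oc1cc(Oc2ccc(C(=O)N3CCC3)cc2)cc(C(=O)Nc2ccn(C)n2)c1` stands second highest of the three numbers so far in a physicochemical assay for lipophilicity (on this read-out higher numbers stand for higher lipophilicity and lower numbers for lower lipophilicity), where compound 3 gives 2.5. Its nearest neighbour is compound 2 `Cc1cnc(NC(=O)c2cc(Oc3ccc(C(=O)N4CCC4)cc3)cc(O[C@@H](C)CO)c2)cn1`, which in this assay gives 2.4, a gap within the scatter. The furthest is compound 1 `CC(C)Oc1cc(Oc2ccc(C(=O)N3CCC3)cc2)cc(C(=O)Nc2ccn(C)n2)c1`, which gives 3.3. Among the compounds with values here, the only measured step that touches the same side chain is a number 0.80 log units lower from compound 1 to compound 3 (beyond the scatter), a modest drop that came with the methoxy being put in place of hydrogen.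

Compound 4 `C[C@@H](CO)Oc1cc(Oc2ccc(C(=O)N3CCC3)cc2)cc(C(=O)Nc2ccn(C)n2)c1` is the compound still to be measured. Its change from compound 3 is hydrogen in place of methyl on an oxygen on a saturated carbon. Cut one bond further out, this reads methoxy to hydroxy, so the same single carbon that the earlier step added is now taken away again, leaving a hydroxymethyl group. Small, polar ethers turned into alcohols usually lower a distribution coefficient by a modest amount, and compound 2 with its own hydroxymethyl side chain gives 2.4, which is consistent with such a level. Compound 4 is therefore expected to give 1.9, with a likely range from 1.5 to 2.4. That would amount to an expected step of a number 0.60 log units lower from compound 3 to compound 4 (beyond the scatter), downward and beyond the scatter.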

Compound 4, distribution coefficient: 1.8
Compound 4: middle estimate off by 0.10 log units, on the high side; the range from low to high includes it.
By their numbers in this assay, from the lowest: compound 4; then compounds 2 and 3 (each within the scatter of the next); then compound 1.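

In this assay the swap of methoxy for hydroxy on this side chain gives a number 0.70 log units lower from compound 3 to compound 4 (beyond the scatter) and shows that removing this single methyl is enough to move the number clearly. Measured from the same starting point, the hydroxy goes further down, with a number 1.50 log units lower from compound 1 to compound 4 (beyond the scatter) against a number 0.80 log units lower from compound 1 to compound 3 (beyond the scatter) for the methoxy, so the two side-chain ends do not read alike at this position. With the hydroxymethyl end held fixed, 1-methyl-1H-pyrazol-3-yl in place of 5-methylpyrazin-2-yl on the amide-type nitrogen gives a number 0.60 log units lower from compound 2 to compound 4 (beyond the scatter) and shows that the group at this second place also moves the number. Nothing measured here explains why these numbers shift.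

On these data alone, how a primary amine or a carboxylic acid in place of the hydroxy would read in this assay remains open, as does a longer chain carrying the hydroxy further out. Also open, as far as these compounds go, is whether the methoxy to hydroxy step would keep its size with 5-methylpyrazin-2-yl on the amide-type nitrogen.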